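The source may report more compounds than this note shows. Statements on the series, on what has been measured and on what is new or still open speak of the compounds shown alone.

Of the compounds shown here, three sharing one core have been tested in a functional assay on HepG2 cells (Homo sapiens) for antiproliferative activity, read by MTT assay, with a stated time of 48 h; on this read-out higher numbers stand for weaker inhibition and lower numbers for stronger inhibition. Compound 1, `Cc1ccccc1-n1nncc1CN1C(=O)C2(C(C#N)=C(N)Oc3c2c2nc4ccccc4nc2c2ccccc32)c2ccccc21`, gives in this assay > 50000 nM, which is a limit of the assay and not a number. Compound 2, `N#CC1=C(N)Oc2c(c3nc4ccccc4nc3c3ccccc23)C12C(=O)N(Cc1cnnn1-c1ccc(N)cc1)c1ccccc12`, gives in this assay > 50000 nM, again only a limit. The step that the two limits leave unreadable from compound 1 to compound 2 is accordingly left unreadable by the two limits. Compound 3, `N#CC1=C(N)Oc2c(N)cc3nc4ccccc4nc3c2C12C(=O)N(Cc1cnnn1-c1ccc(Cl)cc1)c1ccccc12`, gives in this assay > 50000 nM, also a limit. Compound 3 thus stands at the limit of > 50000 nM in this assay, at which 3 of the 3 values shown sit, and no value shown for any compound rises above that limit.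

Compound 4, `CCc1cccc(CC)c1-n1nncc1CN1C(=O)C2(C(C#N)=C(N)Oc3c(N)cc4nc5ccccc5nc4c32)c2ccccc21`, has not yet been measured in this assay. It differs from compound 3 by 2,6-diethylphenyl in place of 4-chlorophenyl on an aromatic nitrogen. For the measured compounds named here, no measured step involves this change, and the one single-point step available, a step that the two limits leave unreadable from compound 1 to compound 2, shows no readable size, so nothing here points to a step beyond the scatter in either direction. Compound 4 is therefore expected to give an estimated 50000 nM, with a range from 20000 nM to 150000 nM, most likely reported again as a limit. The expected step is estimated as a number no higher from compound 3 to compound 4 (the limit leaves the size open).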

Compound 4, half-maximal inhibitory concentration: 16500 nM
The estimate for compound 4 lay 3.0-fold (0.48 log units) above the measured number; the measured number lies below the stated range.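

In this assay, putting 2,6-diethylphenyl in place of 4-chlorophenyl on the aromatic nitrogen of the five-membered ring gives an at least 3.0-fold lower number from compound 3 to compound 4 (0.48 log units; beyond the scatter). For the compounds shown here, this is the first readable sign that the group at this position can shift the read-out, since the earlier step between compounds with a limit on both sides cannot be read. Compound 4 is also the only compound shown that gives a number and not a limit: the limit of > 50000 nM in this assay, at which 3 of the 4 values shown sit.

The compounds shown leave open whether the step depends on the two ethyl groups, the absence of chlorine, or both, and whether a plain phenyl, methyl groups in place of the ethyl groups, or longer chains such as propyl would give a similar number. They also leave open whether 2,6-diethylphenyl would give a comparable step on the core of compound 1.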